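A few compounds are considered here, and "the series" means these few. Any claim that something is new, unique, unknown or untested is made for them only; others in the source may bear on it.

Series notes. In an ADME assay on SK-OV-3 cells (Homo sapiens) for cytotoxicity, read by sulforhodamine B assay, with a stated time of 48 h, tested at 10 uM (on this read-out higher numbers stand for more inhibition at the one concentration tested (going by the name of the read-out) and lower numbers for less inhibition), compound 1 `CCCCCCCc1cn(C(c2ccccc2)c2cc3cc(Br)ccc3nc2OC)nn1` gives 10.5%. Compound 2 `CCCCc1cn(C(c2ccccc2)c2cc3cc(Br)ccc3nc2OC)nn1` gives 11.1%, and compound 3 `COc1nc2ccc(Br)cc2cc1C(c1ccccc1)n1cc(CCCO)nn1` gives 13.8%. Compound 3 holds the highest of the three numbers, but the gaps are small: a number 2.7 percentage points higher from compound 2 to compound 3 (within the scatter) and a number 3.3 percentage points higher from compound 1 to compound 3 (within the scatter), so the three compounds are not separated. The step of a number 0.6 percentage points higher from compound 1 to compound 2 (within the scatter) is likewise flat. Compound 4 `COc1nc2ccc(Br)cc2cc1C(c1ccccc1)n1cc(-c2ccc(OC(F)(F)F)cc2)nn1` differs from compound 3 by 4-(trifluoromethoxy)phenyl in place of 3-hydroxypropyl on an aromatic carbon. Within the data shown here, the steps that alter the group on the same aromatic carbon, those from compound 1 and compound 2 to compound 3, are the only guide, and each stayed within the scatter; the new change exchanges far more atoms than any of them, yet nothing points to a direction, so no step beyond the scatter is expected, with a number 2.2 percentage points higher from compound 3 to compound 4 (within the scatter) as the estimated step. Compound 4 is expected to give 16%, between 2% and 36%.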

Compound 4, a percentage reported as inhibition, at one concentration (the size of the read-out at that concentration, not a potency): 14.8%
For compound 4 the middle estimate is 1.2 percentage points above the measured one; the range from low to high includes it.
By their numbers in this assay, from the lowest: compounds 1, 2, 3 and 4 (each within the scatter of the next).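

Placing 4-(trifluoromethoxy)phenyl on this aromatic carbon brings an aromatic ring to a position that otherwise carries only open chains, yet a number 1 percentage points higher from compound 3 to compound 4 (within the scatter) and a number 3.7 percentage points higher from compound 2 to compound 4 (within the scatter) and a number 4.3 percentage points higher from compound 1 to compound 4 (within the scatter) all stay within the scatter in this assay. Across 3-hydroxypropyl, butyl, heptyl and this far larger ring-bearing group, the position has not yet produced a separable step. Nothing measured here bears on the reason for this flat result. Going by these compounds, whether an amine or a carboxylic acid on this carbon would give a step beyond the scatter remains open.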